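Side-chain step from compound 3 to compound 4

This account rests on a few compounds, and the source may have more. Where it says the series, first, only, none or still open, it means among the compounds named here.

In a functional assay on LoVo cells (Homo sapiens) for inhibition, read by MTT assay, with a stated time of 48 h (a lower number here means a stronger inhibitor, a higher number a weaker inhibitor), compound 3 `COc1ccc(N(C)c2nc(C)nc3ccccc23)cc1OCCCCCC[Se]C#N` gives 8580 nM, the highest number in the series, against compound 2 `COc1ccc(N(C)c2nc(C)nc3ccccc23)cc1C(=O)OCC[Se]C#N` at 2960 nM and compound 1 `COc1ccc(N(C)c2nc(C)nc3ccccc23)cc1OCCC[Se]C#N` at 921 nM. Compound 4 `COc1ccc(N(C)c2nc(C)nc3ccccc23)cc1C(=O)OCCC[Se]C#N` differs from compound 3 by a group of 9 heavy atoms (5 carbon, 1 nitrogen, 2 oxygen, 1 selenium; no ring) in place of a group of 10 heavy atoms (7 carbon, 1 nitrogen, 1 oxygen, 1 selenium; no ring), on an aromatic carbon. Compound 2 shares the ester link of compound 4, so a 2.9-fold higher number from compound 2 to compound 3 (0.46 log units; beyond the scatter) is the closest guide, read in reverse. Compound 1 carries the same chain length as compound 4, and a 9.3-fold higher number from compound 1 to compound 3 (0.97 log units; beyond the scatter) and a 3.2-fold higher number from compound 1 to compound 2 (0.51 log units; beyond the scatter) frame the likely size. A modest move to a lower number is therefore expected in this assay, with the expected step being a 4.3-fold lower number from compound 3 to compound 4 (0.63 log units; beyond the scatter). Compound 4 is estimated at 2000 nM, with an expected range of 700 nM to 5500 nM.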

Compound 4, half-maximal inhibitory concentration: 854 nM
The estimate for compound 4 lay 2.3-fold (0.37 log units) above the measured number; the measured number falls inside the stated range.
By their numbers in this assay, from the lowest: compounds 4 and 1 (each within the scatter of the next); then compound 2; then compound 3.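

In this assay, lengthening the chain on the ester link gives a 3.5-fold lower number from compound 2 to compound 4 (0.54 log units; beyond the scatter) and so shows that chain length counts on the ester as well as on the ether. The ester and ether links at this chain length cannot be separated, with a 1.1-fold lower number from compound 1 to compound 4 (0.03 log units; within the scatter) within the scatter, while a 10-fold lower number from compound 3 to compound 4 (1.00 log units; beyond the scatter) shows that the group entering on this aromatic carbon recovers the number lost with the group that leaves. No measurement shown bears on the reason for these steps.

Still open, from the compounds shown here alone, is whether a longer chain on the ester link would raise the number as far as in compound 3. An amide in place of the ester also remains untested among the compounds shown here.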